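This account rests on a few compounds, and the source may have more. Where it says the series, first, only, none or still open, it means among the compounds named here.

Compound 1 `Oc1cccc(-c2cc(-c3cccnc3)nc(-c3ccccc3Cl)c2)c1` gives 0% in an assay on isolated protein for inhibition of DNA topoisomerase 1 (Homo sapiens), with a stated time of 30 min, tested at 100 uM; a higher number here means a stronger effect of the compound at the concentration tested, a lower number a weaker effect.
Compound 2 `Oc1cccc(-c2cc(-c3cccc(Cl)c3)nc(-c3ccccn3)c2)c1` gives 0.4% in this assay.
Compound 3 `Oc1cccc(-c2cc(-c3ccc(Cl)cc3)nc(-c3ccccn3)c2)c1` gives 30% in this assay.

Compound 3 stands highest of the three, with compound 2 and compound 1 both lower beyond the scatter. For the measured compounds named here, the only step between compounds that differ in one place is a number 29.6 percentage points higher from compound 2 to compound 3 (beyond the scatter), where the chlorine moved from 3-chlorophenyl to 4-chlorophenyl. Compound 4 `Oc1cccc(-c2cc(-c3ccccn3)nc(-c3ccccc3Cl)c2)c1` differs from compound 3 in the same way: 2-chlorophenyl in place of 4-chlorophenyl on an aromatic carbon. That step bears on it most, and it was modest. Compound 1, which also carries a 2-chlorophenyl group, gives 0% in this assay. A drop is therefore expected. Compound 4 is estimated to give 5%, within 0% to 25%. The expected step is a number 25 percentage points lower from compound 3 to compound 4 (beyond the scatter).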

Compound 4, a percentage reported as inhibition, at one concentration (the size of the read-out at that concentration, not a potency): 0%
Compound 4: the middle estimate sits 5 percentage points above what was measured, and the stated range covers the measured number.
By their numbers in this assay, from the lowest: compounds 1, 4 and 2 (each within the scatter of the next); then compound 3.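

Moving the chlorine at this position matters only in one direction: the change to 2-chlorophenyl gives a number 30 percentage points lower from compound 3 to compound 4 (beyond the scatter) in this assay and so leaves the 4-chlorophenyl group of compound 3 alone among the three chlorophenyl isomers in showing a clear read-out, while a number 0.4 percentage points lower from compound 2 to compound 4 (within the scatter) shows that the 2-chlorophenyl and 3-chlorophenyl groups cannot be told apart. With the 2-chlorophenyl group in place, the pyridine change gives no change at the digits printed from compound 1 to compound 4 (within the scatter) and shows no effect in this set. Nothing measured here explains the role of the chlorine position.

Still open, from the compounds shown here alone, is whether an amine or a methoxy group in place of the chlorine of the 4-chlorophenyl group would keep that read-out.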